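Furan-2-yl to phenyl exchange: working notes on the series

This account rests on a few compounds, and the source may have more. Where it says the series, first, only, none or still open, it means among the compounds named here.

Measured values in a functional assay on THP-1 cells (Homo sapiens) for inhibition, read by sulforhodamine B assay, with a stated time of 48 h, tested at 50 uM (a higher number here means more inhibition of growth at the concentration tested, a lower number less inhibition of growth), are as follows.
Compound 1 `COc1cc(/C=C/C(=O)/C=C/c2ccco2)ccc1OCc1cn(CCCOc2cc(=O)oc3ccccc23)nn1` gives 57%
Compound 2 `COc1cc(/C=C/C(=O)/C=C/c2ccco2)ccc1OCc1cn(CCCCCOc2cc(=O)oc3ccccc23)nn1` gives 39%

Compound 1 holds the higher of these two numbers, and compound 2 lies below it by more than the usual scatter. Only these two readings exist so far, so the standing of compound 1 says little about the wider series.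

The next compound is compound 3 `COc1cc(/C=C/C(=O)/C=C/c2ccccc2)ccc1OCc1cn(CCCOc2cc(=O)oc3ccccc23)nn1` which keeps the core of compound 1 and changes one terminal group. The change is phenyl in place of furan-2-yl on a double-bonded chain carbon bound to a double-bonded chain carbon and it amounts to phenyl in place of furan-2-yl on a double-bonded chain carbon bound to a double-bonded chain carbon.

Within the data shown here, no measured pair shows this exchange, so the data give no direct size for it. The expectation rests on compound 1 at 57% as the sole anchor, with a slight downward lean and no shift beyond the scatter expected in this assay for this exchange. The estimated step of a number 5 percentage points lower from compound 1 to compound 3 (within the scatter) is expected to remain within the scatter. For compound 3 the expected value is 52% with an estimated range from 36% to 68% in this read-out.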

Compound 3, percent growth inhibition at one concentration: 48%
Compound 3: the middle estimate sits 4 percentage points above what was measured; the range from low to high includes it.
By their numbers in this assay, from the lowest: compounds 2, 3 and 1 (each within the scatter of the next, the first and the last beyond it).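

In this assay, the exchange of phenyl for furan-2-yl on a double-bonded chain carbon bound to a double-bonded chain carbon now has a measured size, a number 9 percentage points lower from compound 1 to compound 3 (within the scatter). At this place, then, a five-membered aromatic ring with 1 hetero atom and a six-membered aromatic ring of carbon only cannot be told apart in this read-out, although the hydrogen-bond acceptor of furan-2-yl is absent from phenyl; this rests on a single pair, on the core of compound 1, at a single tested concentration. Nothing in the available data gives a reason for this outcome.

As far as these compounds go, whether the exchange gives a step of similar size on the chain of compound 2 remains open, as this one pair speaks only for the chain of compound 1. Also open, from the compounds shown here alone, is how this place responds to terminal groups outside these two rings, such as thiophen-2-yl, pyridin-3-yl, or a phenyl ring carrying an amine or a carboxylic acid, any of which could show whether the terminal group matters here at all.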